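Carbamate in Place of Ester on the Piperidinyl Tail

This account rests on a few compounds, and the source may have more. Where it says the series, first, only, none or still open, it means among the compounds named here.

Compound 1 `CC(C)(C)c1ccc(C(=O)N2CCC3(CC2)C(=O)N(CC(=O)NCCO)CN3c2ccccc2)cc1`: 1000 nM
Compound 2 `CC(C)(C)c1ccc(C(=O)N2CCC3(CC2)C(=O)N(CC(=O)NCCN)CN3c2ccccc2)cc1`: 7000 nM
Compound 3 `CCOC(=O)C1CCN(C(=O)CN2CN(c3ccccc3)C3(CCN(C(=O)c4ccc(C(C)(C)C)cc4)CC3)C2=O)CC1`: 3100 nM

In an assay on HEK293 cells for displacement of a labelled ligand from NPC1-like intracellular cholesterol transporter 1 (Homo sapiens) (a higher number here means a weaker inhibitor, a lower number a stronger inhibitor), compound 3 gives 3100 nM, the second highest of the three numbers; its nearest neighbour is compound 2, a 2.3-fold lower number from compound 2 to compound 3 (0.35 log units; beyond the scatter), and the furthest is compound 1, a 3.1-fold higher number from compound 1 to compound 3 (0.49 log units; beyond the scatter). Compound 4 `CC(C)(C)OC(=O)NCC1CCN(C(=O)CN2CN(c3ccccc3)C3(CCN(C(=O)c4ccc(C(C)(C)C)cc4)CC3)C2=O)CC1` differs from compound 3 at the outer end of the same tail: ((tert-butoxycarbonyl)amino)methyl in place of ethoxycarbonyl on a saturated ring carbon. Within the data shown here, no measured pair changes this carbon in the same way, so only the neighbouring changes on the tail give a sense of scale: a 7.0-fold higher number from compound 1 to compound 2 (0.85 log units; beyond the scatter) and a 3.1-fold higher number from compound 1 to compound 3 (0.49 log units; beyond the scatter) were both modest. Every change to the tail so far has moved the number by a modest amount and in no single direction, so for compound 4 the expected outcome is a step near or only slightly beyond the scatter, a 1.0-fold lower number from compound 3 to compound 4 (0.01 log units; within the scatter), with the direction uncertain. Compound 4 is therefore estimated at 3000 nM, within 800 nM to 12000 nM.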

Compound 4, half-maximal inhibitory concentration: 4200 nM
Compound 4: middle estimate off by 1.4-fold (0.15 log units), on the low side, and the stated range covers the measured number.
By their numbers in this assay, from the lowest: compound 1; then compounds 3, 4 and 2 (each within the scatter of the next, the first and the last beyond it).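

In this assay, ((tert-butoxycarbonyl)amino)methyl in place of ethoxycarbonyl on this saturated ring carbon gives a 1.4-fold higher number from compound 3 to compound 4 (0.13 log units; within the scatter), the first step shown at this carbon and the only tail step shown that stays within the scatter. The entering group has 9 heavy atoms against 5 and adds 1 hydrogen-bond donor, so at this position, three ring bonds from the ring nitrogen, a larger carbamate-bearing group with a donor and the ester read alike. No evidence on the cause bears on this result.

With only these two groups at this carbon, the reading rests on one pair and gives no trend for the position. On these data alone, whether a free aminomethyl group, a carboxylic acid or a longer chain on this carbon would read the same stays open.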